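A Methyl Removed from the Pyridin-2-yl Ring

A few compounds are considered here, and "the series" means these few. Any claim that something is new, unique, unknown or untested is made for them only; others in the source may bear on it.

Compound 1: `C[C@H](/N=C(\S)Nc1ccccn1)c1cccc2ccccc12` — > 100000 nM
Compound 2: `Cc1ccc(N/C(S)=N/[C@H](C)c2cccc3ccccc23)nc1` — 5 nM

Of the compounds shown here, two have been measured in a functional assay on RBL-2H3 cells (Rattus norvegicus) for inhibition; on this read-out lower numbers stand for stronger inhibition and higher numbers for weaker inhibition. For compound 1 the result is a limit of the assay rather than a number, > 100000 nM; this is the limit of > 100000 nM in this assay, at which 1 of the 2 values shown sits. Within the data shown here, compound 2 gives 5 nM in this assay, and it is the only compound of the set with a number rather than a limit.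

Compound 3 is `C[C@@H](/N=C(\S)Nc1ccccn1)c1cccc2ccccc12`. It differs from compound 2 in one place: hydrogen in place of methyl on an aromatic carbon, so that 5-methylpyridin-2-yl becomes pyridin-2-yl. Among the measured compounds shown here, no measured pair of compounds shows this step, so its size cannot be read from the data. A modest loss beyond the scatter, from compound 2 to compound 3, is expected, a 4.0-fold higher number from compound 2 to compound 3 (0.60 log units; beyond the scatter). Compound 3 is therefore estimated at 20 nM in this assay, within a range from 4 nM to 100 nM.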

Compound 3, half-maximal inhibitory concentration: > 100000 nM
Compound 3: a limit, no number; the forecaster's own chance of this, stated with the estimate: 2%; middle value at least 5000-fold (3.69 log units) away from the limit.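

Removing the methyl gives an at least 20000-fold higher number from compound 2 to compound 3 (4.30 log units; beyond the scatter) in this assay, so on this aromatic carbon, two atoms from the ring nitrogen, the change from 5-methylpyridin-2-yl to pyridin-2-yl separates a measured inhibitor from a compound without a measurable value. The value of compound 3, > 100000 nM, is a limit of the assay and not a number, so the true size of the step may be larger still. The step between compound 1 and compound 3 cannot be read, and the stereocentre's contribution with the pyridin-2-yl group stays unknown, because both values sit at the same limit: the limit of > 100000 nM in this assay, at which 2 of the 3 values shown sit.

The compounds shown leave open whether an ethyl group, a chlorine atom or a methoxy group on the same carbon would retain the inhibition seen with methyl. They also leave open how the configuration at the stereocentre acts when the 5-methylpyridin-2-yl group is present.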